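Furan-2-yl Replacing Fluorophenyl: Efficacy Outlook for Compound 4

A few compounds are considered here, and "the series" means these few. Any claim that something is new, unique, unknown or untested is made for them only; others in the source may bear on it.

Compound 1 `O=C(O)Cc1sc(C(c2ccccc2)c2ccccc2)nc1-c1ccc(F)cc1`: 80%
Compound 2 `CS(=O)(=O)Nc1cccc(-c2nc(C(c3ccc(F)cc3)c3ccc(F)cc3)sc2CC(=O)O)c1`: 80%
Compound 3 `O=C(O)Cc1sc(C(c2ccc(F)cc2)c2ccc(F)cc2)nc1-c1cccc(F)c1`: 80%

In an in vitro functional assay on HEK285-7 cells for antagonist activity at prostaglandin D2 receptor 2 (Homo sapiens), read by BRET and beta-arrestin recruitment (a higher number here means a larger maximal response, a lower number a smaller maximal response), compound 1 gives 80%. Compound 2 gives 80%, and compound 3 gives 80%, so all three stand level within the scatter. Among the measured compounds shown here, the only measured step, no change at the digits printed from compound 2 to compound 3 (within the scatter), swapped one group on the aromatic ring at this position and left the efficacy unchanged. Compound 4 `O=C(O)Cc1sc(C(c2ccc(F)cc2)c2ccc(F)cc2)nc1-c1ccco1` is not yet measured; it differs from compound 3 by furan-2-yl in place of 3-fluorophenyl on an aromatic carbon. This exchanges the whole ring rather than a substituent on it, so the measured step is only a loose guide. Since the three measured compounds all sit close together, compound 4 is expected to give 75% (range 55% to 95%). The expected step from compound 3 is a number 5 percentage points lower from compound 3 to compound 4 (within the scatter), essentially none beyond the scatter.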

Compound 4, largest response reached (reported as efficacy), in percent of the reference or control that the assay uses: 80%
Beside the measured number, compound 4's estimate is 5 percentage points below it, within the range that was stated.
By their numbers in this assay, from the lowest: compounds 1, 2, 3 and 4 (each within the scatter of the next).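

Exchanging the whole ring rather than a substituent on it gives no change at the digits printed from compound 3 to compound 4 (within the scatter) in this assay, so this position accepts a five-membered furan-2-yl as readily as a six-membered 3-fluorophenyl. The comparison with the 3-(methanesulfonamido)phenyl group gives no change at the digits printed from compound 2 to compound 4 (within the scatter), so three quite different aromatic rings on this carbon now stand level. No supporting evidence explains this flat result.

From the compounds shown here alone, whether the response would hold with a non-aromatic group on this carbon, such as cyclohexyl or an amine, remains open.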